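This account rests on a few compounds, and the source may have more. Where it says the series, first, only, none or still open, it means among the compounds named here.

Three measured compounds share one core and differ only in the aromatic group carried on the ring nitrogen. In a functional assay on MGC-803 cells (Homo sapiens) for cytotoxicity, read by MTT assay, with a stated time of 72 h (on this read-out higher numbers stand for weaker inhibition and lower numbers for stronger inhibition), compound 1 `FC(F)(F)c1ccc(CSc2nc(Nc3cccc(C(F)(F)F)c3)c3ccccc3n2)cc1` gives 15100 nM. Compound 2 `FC(F)(F)c1ccc(CSc2nc(Nc3cccc(Br)c3)c3ccccc3n2)cc1` gives 23700 nM in this assay, and the change from the first to the second is a 1.6-fold higher number from compound 1 to compound 2 (0.20 log units; within the scatter). Compound 3 `FC(F)(F)c1ccc(CSc2nc(Nc3ccc(C(F)(F)F)cc3)c3ccccc3n2)cc1` gives 6170 nM in this assay, the lowest of the three numbers, reached by a 2.4-fold lower number from compound 1 to compound 3 (0.39 log units; beyond the scatter) and by a 3.8-fold lower number from compound 2 to compound 3 (0.58 log units; beyond the scatter). On these numbers compound 3 is the strongest inhibitor of the set.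

Compound 4 `COc1ccc(Nc2nc(SCc3ccc(C(F)(F)F)cc3)nc3ccccc23)cc1OC` has not yet been measured. It differs from compound 3 by 3,4-dimethoxyphenyl in place of 4-(trifluoromethyl)phenyl on a nitrogen on an aromatic ring. Among the measured compounds shown here, no measured step swaps in this particular group, so there is no direct precedent. The two steps that do alter the group on the nitrogen, a 2.4-fold lower number from compound 1 to compound 3 (0.39 log units; beyond the scatter) and a 3.8-fold lower number from compound 2 to compound 3 (0.58 log units; beyond the scatter), were both of modest size, which suggests that this part of the molecule moves the number only moderately. A modest shift is therefore expected, with the direction uncertain but leaning toward a somewhat higher number. The step from compound 3 to compound 4 is expected to be a 1.6-fold higher number from compound 3 to compound 4 (0.21 log units; within the scatter). The estimate for compound 4 in this assay is 10000 nM, with a range from 3000 nM to 30000 nM.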

Compound 4, half-maximal inhibitory concentration: 16300 nM
The estimate for compound 4 lay 1.6-fold (0.21 log units) below the measured number, and the stated range covers the measured number.
By their numbers in this assay, from the lowest: compound 3; then compounds 1, 4 and 2 (each within the scatter of the next).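

In this assay, putting 3,4-dimethoxyphenyl in place of 4-(trifluoromethyl)phenyl on the nitrogen gives a 2.6-fold higher number from compound 3 to compound 4 (0.42 log units; beyond the scatter) and so loses the advantage of compound 3, which remains the strongest inhibitor of the four. Set against the two groups that carry their substituent in a different place, the new group shows no real difference: the steps are a 1.5-fold lower number from compound 2 to compound 4 (0.16 log units; within the scatter) and a 1.1-fold higher number from compound 1 to compound 4 (0.03 log units; within the scatter) and both stay within the usual scatter, so a group with oxygen atoms and two hydrogen-bond acceptors lands level with 3-bromophenyl and 3-(trifluoromethyl)phenyl, and only 4-(trifluoromethyl)phenyl stands apart. Nothing given here bears on the reason for these differences.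

From the compounds shown here alone, it remains open whether the lower number of compound 3 is particular to 4-(trifluoromethyl)phenyl or would carry over to other groups on this nitrogen, and whether both methoxy groups of compound 4 matter to its number or a phenyl ring with a single methoxy group would read the same. Also open, going by these compounds, is how the number would respond to a phenyl ring bearing an amine or a carboxylic acid, or to a plain alkyl chain in place of the aromatic ring.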